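A few compounds are considered here, and "the series" means these few. Any claim that something is new, unique, unknown or untested is made for them only; others in the source may bear on it.

For the measured compounds named here, compound 1 `O=C(CI)NCCCCCC(=O)NCCCCCCNc1ncnc2c1ncn2[C@@H]1O[C@H](COP(=O)(O)OP(=O)(O)OP(=O)(O)O)[C@@H](O)[C@H]1O` is one of two compounds measured so far. In an assay on isolated protein for inhibition of hexokinase-1 (Rattus norvegicus), with a stated time of 6 h, tested at 10 mM (a lower number here means less inhibition, a higher number more inhibition at the concentration tested (going by the name of the read-out)), compound 1 gives 0%. Compound 2 `O=C(CI)NCCNc1ncnc2c1ncn2[C@@H]1O[C@H](COP(=O)(O)OP(=O)(O)OP(=O)(O)O)[C@@H](O)[C@H]1O` gives in this assay 0%. On these numbers compound 1 stands level with compound 2 at the digits shown, and the two values show no difference beyond the usual scatter of repeated measurements.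

Compound 3 `O=C(CI)NCCCC(=O)NCCCCCCNc1ncnc2c1ncn2[C@@H]1O[C@H](COP(=O)(O)OP(=O)(O)OP(=O)(O)O)[C@@H](O)[C@H]1O` has not yet been measured. It differs from compound 1 in one place: ((iodomethyl)carbonyl)amino in place of 2-(((iodomethyl)carbonyl)amino)ethyl on a saturated chain carbon, three bonds along the chain from a carbonyl carbon. Going by the values given here, no step between measured compounds exists against which such a change could be gauged. What is known is that both measured compounds give no inhibition at all, with nothing to suggest that altering the chain moves the read-out. Compound 3 is therefore expected to show a step of no change at the digits printed from compound 1 to compound 3 (within the scatter), meaning no change beyond the scatter. The estimate for compound 3 is 0%, with a range from 0% to 8%.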

Compound 3, a percentage reported as inhibition, at one concentration (the size of the read-out at that concentration, not a potency): 0%
For compound 3 middle estimate and measured number coincide at the digits printed; measured number inside the range.
By their numbers in this assay, from the lowest: compounds 1, 2 and 3 (each within the scatter of the next).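

In this assay, for the compounds shown here, putting ((iodomethyl)carbonyl)amino in place of 2-(((iodomethyl)carbonyl)amino)ethyl on a saturated chain carbon, three bonds along the chain from a carbonyl carbon, gives no change at the digits printed from compound 1 to compound 3 (within the scatter) as the first direct reading of a change at this position. Going by these compounds alone, this shows that this one change in chain length, with the iodomethyl carbonyl end kept, does not lift the read-out from the floor on which the earlier compounds already sat, though a step between two values at that floor says little about how sensitive the position is. No measurement shown offers an explanation for this result.

As far as these compounds go, whether a longer chain at this position would give any inhibition stays open. So does the effect of replacing the iodomethyl carbonyl end with an amine or a carboxylic acid.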